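A few compounds are considered here, and "the series" means these few. Any claim that something is new, unique, unknown or untested is made for them only; others in the source may bear on it.

Measured in a functional assay on NCI-H157 cells (Homo sapiens) for cytotoxicity, read by resazurin assay, with a stated time of 72 h; on this read-out lower numbers stand for stronger inhibition and higher numbers for weaker inhibition:
- compound 1 `COc1cc(/C=C/C(=O)OCCCCCCO[N+](=O)[O-])ccc1O`: 32100 nM
- compound 2 `COc1cc(/C=C/C(=O)OCCCO[N+](=O)[O-])ccc1O`: 20500 nM

For the measured compounds named here, compound 2 is the starting point and stands level with the only other number in this assay. Going by the values given here, the one measured step is a 1.6-fold lower number from compound 1 to compound 2 (0.19 log units; within the scatter). Compound 3 `COc1cc(/C=C/C(=O)OC/C=C/CO[N+](=O)[O-])ccc1O` follows from compound 2 with a group of 7 heavy atoms (3 carbon, 1 nitrogen, 3 oxygen; no ring) in place of a group of 6 heavy atoms (2 carbon, 1 nitrogen, 3 oxygen; no ring), on a saturated chain carbon bound to an oxygen next to a carbonyl group. Among the compounds with values here, that measured step is the only guide for this chain, and no measured compound has a double bond in it, so the evidence is thin. The expected size is a 1.0-fold lower number from compound 2 to compound 3 (0.01 log units; within the scatter), with no shift expected beyond the scatter. For compound 3 the estimate is 20000 nM, with an estimated range of 9000 nM to 42000 nM.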

Compound 3, half-maximal inhibitory concentration: 4290 nM
Estimate against measurement, compound 3: 4.7-fold (0.67 log units) above, and the stated range ends above it.
By their numbers in this assay, from the lowest: compound 3; then compounds 2 and 1 (each within the scatter of the next).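

In this assay, for the compounds shown here, the unsaturated chain in place of 2-(nitrooxy)ethyl gives a 4.8-fold lower number from compound 2 to compound 3 (0.68 log units; beyond the scatter) and is the first change to move the number beyond the scatter. The earlier chain step, a 1.6-fold lower number from compound 1 to compound 2 (0.19 log units; within the scatter) within the scatter, gave no sign that this position responds to a change in the chain. Nothing on hand explains the new step.

The compounds shown do not separate the double bond from the added carbon. A saturated chain of equal length, or a triple bond in the chain, would bear on this.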